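This account rests on a few compounds, and the source may have more. Where it says the series, first, only, none or still open, it means among the compounds named here.

Compound 1 `CN1CCN(CCCOc2cccc3nc(Nc4ccc(Cl)c(C(F)(F)F)c4)ccc23)CC1` gives 2070 nM in a functional assay on NCI-H226 cells (Homo sapiens) for inhibition, read by sulforhodamine B assay, with a stated time of 48 h; a higher number here means a weaker inhibitor of growth, a lower number a stronger inhibitor of growth. Compound 2 `CN1CCN(CCCOc2cccc3nc(Nc4ccc(Cl)c(F)c4)ccc23)CC1` gives 2050 nM, and compound 3 `CN1CCN(CCCOc2cccc3nc(Nc4cc(Cl)cc(Cl)c4)ccc23)CC1` gives 1950 nM. Compound 3 thus stands together with the other two: a 1.1-fold lower number from compound 1 to compound 3 (0.03 log units; within the scatter) and a 1.1-fold lower number from compound 2 to compound 3 (0.02 log units; within the scatter) leave no separation, and likewise a 1.0-fold lower number from compound 1 to compound 2 (0.00 log units; within the scatter). Compound 4 `CN1CCN(CCCOc2cccc3nc(Nc4cccc(Cl)c4)ccc23)CC1` carries hydrogen in place of chloro on an aromatic carbon. Among the compounds with values here, no measured step removes a group in this way; the steps that bear on it are the exchanges of the aryl group, a 1.1-fold lower number from compound 1 to compound 3 (0.03 log units; within the scatter) and a 1.1-fold lower number from compound 2 to compound 3 (0.02 log units; within the scatter), both within the scatter, and the shared core carries every number so far. The expectation for compound 4 in this assay is therefore a 1.1-fold higher number from compound 3 to compound 4 (0.03 log units; within the scatter), no step beyond the scatter in either direction. Compound 4 is estimated at 2100 nM, with a range of 1000 nM to 4500 nM.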

Compound 4, concentration for 50% growth inhibition: 1620 nM
Compound 4: the middle estimate sits 1.3-fold (0.11 log units) above what was measured, within the range that was stated.
By their numbers in this assay, from the lowest: compounds 4, 3, 2 and 1 (each within the scatter of the next).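

In this assay, within the data shown here, the loss of one chloro from the 3,5-dichlorophenyl group, a 1.2-fold lower number from compound 3 to compound 4 (0.08 log units; within the scatter), is the first removal at this ring rather than an exchange, and it leaves the number within the scatter. A single chloro also holds level with the two larger aryl groups: a 1.3-fold lower number from compound 2 to compound 4 (0.10 log units; within the scatter) and a 1.3-fold lower number from compound 1 to compound 4 (0.11 log units; within the scatter). No supporting measurement accounts for this flat response. Open, going by these compounds, is whether it persists with unsubstituted phenyl, or with an amine or carboxylic acid on this ring. Also open, on these data alone, is how a longer chain in the side arm would read.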